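The source may hold more compounds than are shown below. What is called first, only, known or untested is meant among the compounds shown, and "the series" means these compounds.

Among the compounds with values here, compound 1, `CCN1CCCC1CNC(=O)c1cc(N(C)S(=O)(=O)N(C)C)ccc1OC`, is one of two compounds so far tested in a functional assay on the whole organism for inhibition, with Mus musculus as the target; on this read-out higher numbers stand for an effect only at larger amounts of compound and lower numbers for an effect already at smaller amounts; in this assay compound 1 gives 36.2 mg/kg, and the only other number, that of compound 2, lies within the scatter of it. Compound 2, `CCN1CCCC1CNC(=O)c1cc(N(C)S(=O)(=O)N(C)C)c(Cl)cc1OC`, carries chloro in place of hydrogen on an aromatic carbon and gives 31.8 mg/kg in this assay, so the step of a 1.1-fold lower number from compound 1 to compound 2 (0.06 log units; within the scatter) is too small to count. Compound 3, `CCN1CCCC1CNC(=O)c1cc(NS(N)(=O)=O)ccc1OC`, has not yet been measured in this assay. It differs from compound 1 by sulfamoylamino in place of (dimethylsulfamoyl)(methyl)amino on an aromatic carbon of a six-membered aromatic ring of carbon only, meta to a large group and para to a methoxy group. Within the data shown here, the single measured step concerns another place on the core of compound 1 and says nothing about this exchange; it shows only that one small change left this assay unmoved. Among the measured compounds shown here, with no step that bears directly on the change, the expected step is a 1.0-fold lower number from compound 1 to compound 3 (0.01 log units; within the scatter), not beyond the scatter. Compound 3 is therefore estimated at 35 mg/kg, within a range from 14 mg/kg to 85 mg/kg.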

Compound 3, dose for half-maximal effect: > 50 mg/kg
Compound 3: no number, only a limit; the forecaster's own chance of this, stated with the estimate: 10%; at least 1.4-fold (0.15 log units) between middle value and limit.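

Within the data shown here, at this position, para to a methoxy group, the exchange of (dimethylsulfamoyl)(methyl)amino for sulfamoylamino gives a first reading in this assay of a change on this group, and the step is an at least 1.3-fold higher number from compound 1 to compound 3 (0.14 log units; that floor lies within the scatter). Compound 3 gives > 50 mg/kg, which is a limit of the assay and not a number. The step is therefore only a floor, and it does not show that this exchange moves the read-out beyond the scatter, though it also leaves room for a larger step than the one between the two earlier compounds; everything said about its size rests on a single reading: the limit of > 50 mg/kg in this assay, at which 1 of the 3 values shown sits.

The compounds shown leave open how far the true value of compound 3 lies from that limit, and whether the methyl groups on the sulfamide nitrogens matter singly or only together, as the (dimethylsulfamoyl)amino and methyl(sulfamoyl)amino groups could tell. They also leave open how other groups at this position would read in this assay, such as methanesulfonylamino or a plain amine.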